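Swapping (4-methylphenyl)sulfonyl for hydrogen on an amine nitrogen

A few compounds are considered here, and "the series" means these few. Any claim that something is new, unique, unknown or untested is made for them only; others in the source may bear on it.

Compound 1 `O=C1Nc2ccc(S(=O)(=O)N3CCOCC3)cc2/C1=N/c1cccc(C(F)(F)F)c1`: 15900 nM
Compound 2 `Cc1ccc(S(=O)(=O)N/N=C2\C(=O)Nc3ccc(S(=O)(=O)N4CCOCC4)cc32)cc1`: 23400 nM

In a functional assay on HCT-116 cells (Homo sapiens) for cytotoxicity, read by sulforhodamine B assay, with a stated time of 24 h (on this read-out higher numbers stand for weaker inhibition and lower numbers for stronger inhibition), compound 2 gives 23400 nM, which lies within the usual scatter of compound 1 at 15900 nM. Compound 3 `N/N=C1\C(=O)Nc2ccc(S(=O)(=O)N3CCOCC3)cc21` differs from compound 2 in one place: hydrogen in place of (4-methylphenyl)sulfonyl on an amine nitrogen. Within the data shown here, no measured pair shows this change alone, so the expectation is tentative: no step beyond the scatter and no clear direction, given how close compound 1 at 15900 nM and compound 2 at 23400 nM lie. The expected step is a 1.2-fold lower number from compound 2 to compound 3 (0.07 log units; within the scatter). Compound 3 is estimated at 20000 nM, with an expected range of 7000 nM to 60000 nM.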

Compound 3, half-maximal inhibitory concentration: 36300 nM
For compound 3 the middle estimate is 1.8-fold (0.26 log units) below the measured one; measured number inside the range.
By their numbers in this assay, from the lowest: compounds 1, 2 and 3 (each within the scatter of the next, the first and the last beyond it).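

In this assay, hydrogen in place of (4-methylphenyl)sulfonyl on the amine nitrogen gives a 1.6-fold higher number from compound 2 to compound 3 (0.19 log units; within the scatter) and so shows no clear effect of losing that group. Amino in place of 3-(trifluoromethyl)phenyl on the double-bonded nitrogen gives a 2.3-fold higher number from compound 1 to compound 3 (0.36 log units; beyond the scatter) and is a modest loss of inhibition, the only step here beyond the scatter. Nothing available bears on the cause of either step. Still open, from the compounds shown here alone, is whether an acetyl group or a plain phenyl ring on that amine nitrogen would give a number clearly apart from compound 3.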